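From compound 1 to compound 4: one aryl swap

A few compounds are considered here, and "the series" means these few. Any claim that something is new, unique, unknown or untested is made for them only; others in the source may bear on it.

In an ADME assay on L02 cells (Homo sapiens) for cytotoxicity, read by MTT assay, with a stated time of 24 h (on this read-out higher numbers stand for weaker inhibition and lower numbers for stronger inhibition), compound 1 (`COc1cc(/C=C2\CN(S(=O)(=O)c3ccc(F)cc3)C/C(=C\c3cc(OC)cc(OC)c3)C2=O)cc(OC)c1`) gives 19800 nM. Compound 2 (`CC(=O)Nc1ccc(S(=O)(=O)N2C/C(=C\c3ccccc3F)C(=O)/C(=C/c3ccccc3F)C2)cc1`) gives 11600 nM, and compound 3 (`CC(=O)Nc1ccc(S(=O)(=O)N2C/C(=C\c3cccc([N+](=O)[O-])c3)C(=O)/C(=C/c3cccc([N+](=O)[O-])c3)C2)cc1`) gives 15800 nM. Compound 1 lies within the scatter of both, so these numbers set no order among the three compounds.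

Compound 4 (`COc1cc(/C=C2\CN(S(=O)(=O)c3ccc(F)cc3)C/C(=C\c3ccccc3F)C2=O)cc(OC)c1`) has not yet been measured. Its structure departs from that of compound 1 in one place: 2-fluorophenyl in place of 3,5-dimethoxyphenyl on a double-bonded chain carbon bound to a double-bonded ring carbon. The change is 2-fluorophenyl in place of 3,5-dimethoxyphenyl on a double-bonded chain carbon bound to a double-bonded ring carbon.

Among the measured compounds shown here, no measured pair differs in only one place, so the size of this change has no direct precedent. The nearest guide is compound 2, which also carries 2-fluorophenyl and gives 11600 nM, although the rest of its structure differs from compound 4. The estimated 1.4-fold lower number from compound 1 to compound 4 (0.15 log units; within the scatter) goes toward a lower number but is expected to stay within the scatter. For compound 4 the estimate is 14000 nM, with an expected range of 7000 nM to 28000 nM.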

Compound 4, half-maximal inhibitory concentration: 18500 nM
The estimate for compound 4 lay 1.3-fold (0.12 log units) below the measured number; measured number inside the range.
By their numbers in this assay, from the lowest: compounds 2, 3, 4 and 1 (each within the scatter of the next).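

In this assay the series now has its first step at a single place: a 1.1-fold lower number from compound 1 to compound 4 (0.03 log units; within the scatter) stays within the scatter. At this place, on a double-bonded chain carbon bound to a double-bonded ring carbon, 2-fluorophenyl in place of 3,5-dimethoxyphenyl exchanges 10 heavy atoms for 7 and 2 hydrogen-bond acceptors for 0, with no change in the number beyond the scatter. No measured evidence bears on why this step stays so small.

The compounds shown leave open whether a phenyl carrying an amine or a carboxylic acid at this place would move the number beyond the scatter. Also open, from the compounds shown here alone, is what the same swap would do to the 3,5-dimethoxyphenyl that compound 4 still carries.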